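Trimethoxyphenyl thiocarbonyl series: chloro on the pendant phenyl

The source may hold more compounds than are shown below. What is called first, only, known or untested is meant among the compounds shown, and "the series" means these compounds.

Measured compounds:
compound 1, `COc1ccc(C(=O)CSC(=S)Nc2cc(OC)c(OC)c(OC)c2)cc1`, 18.6 ug/mL
compound 2, `COc1cc(N2C(=S)SCC2(O)c2ccc(Cl)cc2Cl)cc(OC)c1OC`, 9.6 ug/mL
compound 3, `COc1cc(-n2c(-c3ccccc3)csc2=S)cc(OC)c1OC`, > 100 ug/mL

In a functional assay on MCF7 cells (Homo sapiens) for cytotoxicity, read by MTT assay, with a stated time of 48 h (a lower number here means a stronger inhibitor, a higher number a weaker inhibitor), compound 3 gives only a limit, > 100 ug/mL. That value sits at the limit of > 100 ug/mL in this assay, at which 1 of the 3 values shown sits. Among the compounds with values here, compound 1 gives 18.6 ug/mL and compound 2 gives 9.6 ug/mL in this assay; neither shares the core of compound 3, so no step to compound 3 is counted.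

Compound 4, `COc1cc(-n2c(-c3ccc(Cl)cc3)csc2=S)cc(OC)c1OC`, differs from compound 3 by chloro in place of hydrogen on an aromatic carbon, para to a large group. Within the data shown here, no measured step of this kind exists. The expected step of an at least 1.1-fold lower number from compound 3 to compound 4 (0.04 log units; that floor lies within the scatter) is small and uncertain, and compound 4 is estimated at 90 ug/mL, between 30 ug/mL and 300 ug/mL, most likely again a limit.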

Compound 4, half-maximal inhibitory concentration: > 100 ug/mL
Compound 4 was reported as a limit; the forecaster's own chance of this, stated with the estimate: 55%; at least 1.1-fold (0.04 log units) between middle value and limit.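

No step can be read from compound 3 to compound 4, as each gives only a limit: the limit of > 100 ug/mL in this assay, at which 2 of the 4 values shown sit.
The compounds shown leave open whether chloro in place of hydrogen on an aromatic carbon changes activity on this core.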